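Swapping the pyrazole back for a pyridine

A few compounds are considered here, and "the series" means these few. Any claim that something is new, unique, unknown or untested is made for them only; others in the source may bear on it.

Of the compounds shown here, three of a shared core have been measured in a functional assay on MCF7 cells (Homo sapiens) for antiproliferative activity, read by sulforhodamine B assay, with a stated time of 72 h; a lower number here means a stronger inhibitor, a higher number a weaker inhibitor. Compound 1 `COc1ncc(-c2ccc3ncnc(Nc4ccc(OCCCO)nc4)c3c2)cc1NS(=O)(=O)c1ccc(F)cc1F` gives 6120 nM, compound 2 `COc1ncc(-c2ccc3ncnc(Nc4ccc(OCCO)nc4)c3c2)cc1NS(C)(=O)=O` gives 3080 nM, and compound 3 `COc1ncc(-c2ccc3ncnc(Nc4cnn(CCCO)c4)c3c2)cc1NS(=O)(=O)c1ccc(F)cc1F` gives 1310 nM. On these numbers compound 3 stands lowest of the three, with compound 2 nearest and compound 1 furthest away. Compound 4 `COc1ncc(-c2ccc3ncnc(Nc4ccc(OCCO)nc4)c3c2)cc1NS(=O)(=O)c1ccc(F)cc1F` is not yet measured in this assay; it differs from compound 3 in one place: 6-(2-hydroxyethoxy)pyridin-3-yl in place of 1-(3-hydroxypropyl)-1H-pyrazol-4-yl on a nitrogen on an aromatic ring. Going by the values given here, one measured step bears directly on this exchange: a 4.7-fold lower number from compound 1 to compound 3 (0.67 log units; beyond the scatter), where the pyrazolyl replaced the pyridinyl and the number fell. Among the compounds with values here, compound 4 reverses that exchange, but with the 2-hydroxyethoxy chain rather than the 3-hydroxypropoxy chain; compound 2 carries the same 6-(2-hydroxyethoxy)pyridin-3-yl on the nitrogen with a different sulfonyl, and its value sits between those of compound 1 and compound 3, but no single step links it to compound 4. The expectation for compound 4 in this assay is therefore a rise, roughly undoing the step from compound 1 to compound 3, estimated as a 3.4-fold higher number from compound 3 to compound 4 (0.54 log units; beyond the scatter). Compound 4 is expected to give about 4500 nM, within a range from 1800 nM to 11000 nM.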

Compound 4, half-maximal inhibitory concentration: 4300 nM
For compound 4 the middle estimate is 1.0-fold (0.02 log units) above the measured one; low and high end bracket the measured number.
By their numbers in this assay, from the lowest: compound 3; then compounds 2, 4 and 1 (each within the scatter of the next).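

In this assay, going by these compounds alone, the step of a 3.3-fold higher number from compound 3 to compound 4 (0.52 log units; beyond the scatter) lies beyond the scatter and points the same way as the earlier 4.7-fold lower number from compound 1 to compound 3 (0.67 log units; beyond the scatter), so the lower number with 1-(3-hydroxypropyl)-1H-pyrazol-4-yl on this nitrogen now holds against two pyridinyl groups, not only the one with the 3-hydroxypropoxy chain. The chain on the pyridine makes no readable difference: the step of a 1.4-fold lower number from compound 1 to compound 4 (0.15 log units; within the scatter), which replaces hydroxymethyl with hydroxy on the saturated chain carbon, lies within the scatter. Neither does the group on the sulfonyl sulfur with 6-(2-hydroxyethoxy)pyridin-3-yl in place, as the step of a 1.4-fold higher number from compound 2 to compound 4 (0.14 log units; within the scatter), 2,4-difluorophenyl in place of methyl, also lies within the scatter.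

Nothing available accounts for the gap between the pyrazolyl and pyridinyl groups, so the reason for it stays unknown. The compounds shown also leave open whether a 1-(2-hydroxyethyl)-1H-pyrazol-4-yl group, a methyl on the sulfonyl sulfur alongside the pyrazolyl group, or an amine in place of the hydroxy on either chain would keep the number as low as in compound 3.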